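Notes on the step from compound 1 to compound 3

This account rests on a few compounds, and the source may have more. Where it says the series, first, only, none or still open, it means among the compounds named here.

Measured in an ADME assay on microsomes from liver (Homo sapiens) for metabolic stability, read by LC-MS, with a stated time of 30 min, tested at 1 uM; a higher number here means that more of the compound is left, a lower number that less of the compound is left:
- compound 1 `Cc1ccccc1S(=O)(=O)c1ccc(CNC(=O)c2cc3cnccc3[nH]2)cc1`: 48%
- compound 2 `O=C(NCc1ccc(S(=O)(=O)c2ccccc2)cc1)c1ccc2ncncc2c1`: 24%

Compound 1 gives 48% and compound 2 gives 24%, which leaves compound 1 the higher of the two, beyond the scatter. Compound 3 `O=C(NCc1ccc(S(=O)(=O)c2ccc(F)c(F)c2)cc1)c1cc2cnccc2[nH]1` remains unmeasured. It differs from compound 1 in one place: 3,4-difluorophenyl in place of 2-methylphenyl on a sulfonyl sulfur, with 3,4-difluorophenyl in place of 2-methylphenyl on a sulfonyl sulfur. For the measured compounds named here, no measured pair isolates this change, so the expectation in this assay is tentative. The expected step is a number 7 percentage points higher from compound 1 to compound 3 (within the scatter), a small rise that stays within the scatter. For compound 3 the estimated value is 55%, with an expected range of 35% to 75%.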

Compound 3, percent of the compound remaining: 100%
Compound 3: middle estimate off by 45 percentage points, on the low side; measured number outside the range, above it.
By their numbers in this assay, from the lowest: compound 2; then compound 1; then compound 3.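

The sulfonyl sulfur's aryl group is a sensitive position in this assay: with the core held fixed, the series shows a number 52 percentage points higher from compound 1 to compound 3 (beyond the scatter) on exchanging 2-methylphenyl for 3,4-difluorophenyl. For the compounds shown here, this is the first comparison here that isolates a change in one place, as compound 1 and compound 2 differ in more than one. No measurement at hand bears on the reason for this step.

As far as these compounds go, it remains open whether a single fluorine would give a similar step, or whether chlorine or methoxy on that ring would. Also open, from the compounds shown here alone, is whether 3,4-difluorophenyl carries the same step on the core of compound 2.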